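A few compounds are considered here, and "the series" means these few. Any claim that something is new, unique, unknown or untested is made for them only; others in the source may bear on it.

In a functional assay on SF-539 cells (Homo sapiens) for inhibition, read by sulforhodamine B assay, with a stated time of 48 h (on this read-out lower numbers stand for stronger inhibition of growth and higher numbers for weaker inhibition of growth), compound 1 `O=C(Cc1csc2nc(-c3ccc(Br)cc3)cn12)N/N=C/c1ccccc1` gives 16200 nM. Among the compounds with values here, compound 2 `O=C(Cc1csc2nc(-c3ccc(Br)cc3)cn12)N/N=C/c1ccccc1O`, which carries hydroxy in place of hydrogen on an aromatic carbon, gives 3550 nM, the lower of the two numbers so far. The step is a 4.6-fold lower number from compound 1 to compound 2 (0.66 log units; beyond the scatter), modest but beyond the scatter. Compound 3 `O=C(Cc1csc2nc(-c3ccc(Br)cc3)cn12)N/N=C/c1ccc(O)cc1` has not yet been measured. It has 4-hydroxyphenyl in place of the 2-hydroxyphenyl of compound 2, on a carbon with a double bond to nitrogen: 4-hydroxyphenyl in place of 2-hydroxyphenyl on a carbon with a double bond to nitrogen. The hydroxy group is therefore kept, but it stands elsewhere on the phenyl group. Within the data shown here, only one measured step bears on this change, a 4.6-fold lower number from compound 1 to compound 2 (0.66 log units; beyond the scatter), and it shows what adding the group at the 2-hydroxyphenyl arrangement did, not what the 4-hydroxyphenyl arrangement will do. The expectation is that part of that modest gain is kept and part is lost, giving a higher number of similar or smaller size, near the edge of the scatter. For compound 3 the estimated value is 6500 nM, with an expected range from 2500 nM to 17000 nM. The expected change is a 1.8-fold higher number from compound 2 to compound 3 (0.26 log units; within the scatter).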

Compound 3, concentration for 50% growth inhibition: 18200 nM
Compound 3: the middle estimate sits 2.8-fold (0.45 log units) below what was measured; measured number outside the range, above it.
By their numbers in this assay, from the lowest: compound 2; then compounds 1 and 3 (each within the scatter of the next).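

Moving the hydroxy group, so that 4-hydroxyphenyl stands in place of 2-hydroxyphenyl, gives a 5.1-fold higher number from compound 2 to compound 3 (0.71 log units; beyond the scatter) in this assay and shows that the same atoms joined differently do not read alike at this position. Set against the compound with no hydroxy group, the 4-hydroxyphenyl arrangement brings no gain, the step being a 1.1-fold higher number from compound 1 to compound 3 (0.05 log units; within the scatter) and so within the scatter, which means that among these three compounds the lower number belongs to the 2-hydroxyphenyl arrangement alone and not to the presence of a hydroxy group as such. No measurement in hand accounts for the difference between the two arrangements. What the compounds shown leave open is whether a methoxy group or an amine, standing where the hydroxy group of 2-hydroxyphenyl stands, would keep the lower number or lose it. Also open, from the compounds shown here alone, is whether the gap between the two arrangements holds when chlorine replaces the bromine on the shared core.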